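A few compounds are considered here, and "the series" means these few. Any claim that something is new, unique, unknown or untested is made for them only; others in the source may bear on it.

In a functional assay on Caco-2 cells (Homo sapiens) for inhibition, read by MTT assay, with a stated time of 48 h, tested at 10 uM (a higher number here means more inhibition of growth at the concentration tested, a lower number less inhibition of growth), compound 1 `Cc1cc(=O)c2c(O)c(CN3CCCC3)c(O)c([C@H]3CCN(C)C[C@H]3O)c2o1` gives 22%, compound 2 `Cc1oc2c([C@H]3CCN(C)C[C@H]3O)c(O)cc(O)c2c(=O)c1C(O)c1ccc(Cl)cc1` gives 3% and compound 3 `Cc1oc2c([C@H]3CCN(C)C[C@H]3O)c(O)cc(O)c2c(=O)c1C(O)c1cccc(Cl)c1` gives 4%. Compound 3 therefore sits within the scatter of compound 2, and the value of compound 1 is clearly higher than both.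

Compound 4 `Cc1oc2c([C@H]3CCN(C)C[C@H]3O)c(O)cc(O)c2c(=O)c1C(O)c1ccc(F)c(Br)c1` keeps the core of compound 3 and alters a single group: 3-bromo-4-fluorophenyl in place of 3-chlorophenyl on a saturated chain carbon bound to an aromatic carbon and an oxygen on a saturated carbon. Here 3-bromo-4-fluorophenyl stands in place of 3-chlorophenyl, on a saturated chain carbon bound to an aromatic carbon and an oxygen on a saturated carbon.

Among the measured compounds shown here, one measured step bears on this same place, the swap of 4-chlorophenyl for 3-chlorophenyl. It amounts to a number 1 percentage points higher from compound 2 to compound 3 (within the scatter), which is a very small step. Compound 1 differs from compound 3 in more than one place, so it offers little guidance here. The new group has not been tested, so some uncertainty remains, but no step beyond the scatter is expected in this assay.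

The expected change is a number 2 percentage points higher from compound 3 to compound 4 (within the scatter).

The estimate for compound 4 is 6%, with an expected range of 0% to 16%.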

Compound 4, percent growth inhibition at one concentration: 6%
Compound 4: middle estimate and measured number agree at the digits printed, within the range that was stated.
By their numbers in this assay, from the lowest: compounds 2, 3 and 4 (each within the scatter of the next); then compound 1.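

In this assay, putting 3-bromo-4-fluorophenyl in place of 3-chlorophenyl gives a number 2 percentage points higher from compound 3 to compound 4 (within the scatter), and putting it in place of 4-chlorophenyl gives a number 3 percentage points higher from compound 2 to compound 4 (within the scatter). The earlier compounds shown here showed only that one chlorine could take two places on the phenyl ring; compound 4 adds a phenyl ring with two halogens, bromine and fluorine, and one more heavy atom, and among compounds 2, 3 and 4 this still brings no step beyond the scatter. Nothing available here offers an explanation for this result.

All three of these compounds carry a halogen-bearing phenyl ring at this position, so it remains open how an amine, a carboxylic acid or a longer chain would read there. As far as these compounds go, compound 1, at 22%, differs from them in more than one place, so which of its groups goes with that number also stays open.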